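Sulfone in place of a nitro group on the side chain

The source may report more compounds than this note shows. Statements on the series, on what has been measured and on what is new or still open speak of the compounds shown alone.

Measured compounds:
compound 1, `CC(OCn1cc[n+](C)c1/C=N/O)C(C)S(C)(=O)=O`, -2.09; -2.79 (2 entries) in a physicochemical assay for lipophilicity; a higher number here means a more lipophilic compound, a lower number a more polar compound
compound 2, `CCN(CCn1cc[n+](C)c1/C=N/O)S(=O)(=O)C(F)(F)F`, -1.03 in this assay
compound 3, `CC[n+]1ccn(COCC(C)(C)[N+](=O)[O-])c1/C=N/O`, -1.77 in this assay

Compound 3 stands at the lowest of the two single numbers in this assay; compound 2 sits higher, by a gap beyond the usual scatter. Compound 1 appears with two entries rather than one number, and the spread between them is shown by the several entries of compound 1 in this assay, -2.09; -2.79 (2 entries), so its place against compound 3 cannot be fixed.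

Compound 4, `CC[n+]1ccn(COCCS(=O)(=O)CC)c1/C=N/O`, has not yet been measured in this assay. It differs from compound 3 in one place: (ethylsulfonyl)methyl in place of 1-methyl-1-nitroethyl on a saturated chain carbon bound to an oxygen on a saturated carbon. Among the measured compounds shown here, no step between two measured compounds isolates this exchange, so the expectation for compound 4 rests only on where compound 3 stands and on the character of the entering group as counted. The step from compound 3 to compound 4 is expected to be a modest move downward, a number 0.43 log units lower from compound 3 to compound 4 (beyond the scatter), though it may stay within the scatter. Compound 4 is estimated at -2.2 in this assay, with a range from -2.9 to -1.5.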

Compound 4, distribution coefficient: -2.67
Compound 4: middle estimate off by 0.47 log units, on the high side; low and high end bracket the measured number.
By their numbers in this assay, from the lowest: compound 4; then compound 3; then compound 2.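

In this assay, among the compounds shown here, the exchange of 1-methyl-1-nitroethyl for (ethylsulfonyl)methyl on a saturated chain carbon bound to an oxygen on a saturated carbon now has a direct reading, which the earlier compounds did not give: a number 0.90 log units lower from compound 3 to compound 4 (beyond the scatter). The exchange keeps the counts of heavy atoms, hydrogen-bond donors and hydrogen-bond acceptors level, and neither group carries a net charge, so these counts do not track the step. This single step should be read alongside the spread seen in the other sulfone-bearing compound: the several entries of compound 1 in this assay, -2.09; -2.79 (2 entries)

From the compounds shown here alone, what an amide or a longer alkyl chain would give at this place remains open. So does whether the same exchange would give a step of similar size on a different side chain.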